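The source may hold more compounds than are shown below. What is called first, only, known or untested is meant among the compounds shown, and "the series" means these compounds.

Measured compounds:
Compound 1 `O=C(Nc1ccc(Cl)c(-c2nnc3c(Cl)cccn23)c1)c1ccc(Cl)cc1`: > 100000 nM
Compound 2 `O=C(Nc1ccc(Cl)c(-c2nnc3c(Cl)cccn23)c1)c1cccnc1Cl`: 89700 nM

In a functional assay on MDA-MB-231 cells (Homo sapiens) for antiproliferative activity, read by MTT assay, with stated times of 72 h and 4 h (on this read-out higher numbers stand for weaker inhibition and lower numbers for stronger inhibition), compound 1 gives only a limit of the assay, > 100000 nM, and no number. Where compound 1 stands is therefore fixed only by the limit of > 100000 nM in this assay, at which 1 of the 2 values shown sits, at which one of the two values sits. In this assay compound 2 gives 89700 nM. Going by the values given here, the one measured step, an at least 1.1-fold lower number from compound 1 to compound 2 (0.04 log units; that floor lies within the scatter), sits on a floor that lies within the scatter and shows no change beyond it.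

Compound 3 `CS(=O)(=O)c1cccc(C(=O)Nc2ccc(Cl)c(-c3nnc4c(Cl)cccn34)c2)c1` is not yet measured in this assay. Its difference from compound 1 is 3-(methylsulfonyl)phenyl in place of 4-chlorophenyl on a carbonyl carbon. Among the compounds with values here, the only measured step, 2-chloropyridin-3-yl in place of 4-chlorophenyl on a carbonyl carbon, is a different exchange at the same carbonyl carbon and gives no more than an indication that this part of compound 1 tolerates change without a shift beyond the scatter. For compound 3 the expected step is an at least 1.0-fold lower number from compound 1 to compound 3 (0.02 log units; that floor lies within the scatter), that is, none beyond the scatter. Compound 3 is therefore estimated at 95000 nM, with a range from 30000 nM to 300000 nM, and a real chance that only a limit is returned.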

Compound 3, half-maximal inhibitory concentration: > 100000 nM
Compound 3 was reported as a limit; the forecaster's own chance of this, stated with the estimate: 55%; middle value at least 1.0-fold (0.02 log units) from the limit.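

In this assay compound 3 gives > 100000 nM, a limit of the assay and not a number, and with compound 1 also standing at a limit, the step between these two compounds cannot be read. Going by these compounds, exchanging 2-chloropyridin-3-yl for 3-(methylsulfonyl)phenyl on a carbonyl carbon gives an at least 1.1-fold higher number from compound 2 to compound 3 (0.04 log units; that floor lies within the scatter), so the readable part of the result shows no change beyond the scatter, although the true size of the step remains unknown. New in this result is that a group with a sulfonyl function and hydrogen-bond acceptors at this carbonyl carbon also gives no number, which leaves the series here at: the limit of > 100000 nM in this assay, at which 2 of the 3 values shown sit.

The compounds shown leave open whether any group at this carbonyl carbon can bring the value clearly below this level, for instance a phenyl ring carrying a carboxylic acid or an amine, or a saturated chain in place of the ring. They also leave open whether changes elsewhere on the shared core would move the value, as all three compounds differ in this one place only.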